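Three inactive compounds and a fourth to estimate

A few compounds are considered here, and "the series" means these few. Any claim that something is new, unique, unknown or untested is made for them only; others in the source may bear on it.

Compound 1 `CC(C)(C)c1ccc(Cn2c(Cl)nc3cc(Cl)c(Cl)cc32)cc1` was tested in a functional assay on CEM-SS cells (Homo sapiens) for cytotoxicity; on this read-out lower numbers stand for stronger inhibition and higher numbers for weaker inhibition. Compound 1 gives > 100000 nM, which is a limit of the assay rather than a number. Compound 2 `FC(F)(F)c1ccc(Cn2c(Cl)nc3cc(Cl)c(Cl)cc32)cc1` differs from compound 1 by trifluoromethyl in place of tert-butyl on an aromatic carbon. Compound 2 gives > 100000 nM, again a limit. The step that the two limits leave unreadable from compound 1 to compound 2 therefore cannot be sized. Compound 3 `CC(C)(C)c1ccc(Cn2c(Br)nc3cc(Cl)c(Cl)cc32)cc1` has a different core, and the two cores differ by bromo in place of chloro on an aromatic carbon. Compound 3 gives > 100000 nM, also a limit, so a step that the two limits leave unreadable from compound 1 to compound 3 is unreadable as well. All three values sit at the limit of > 100000 nM in this assay, at which 3 of the 3 values shown sit. Compound 4 `FC(F)(F)c1ccc(Cn2c(Br)nc3cc(Cl)c(Cl)cc32)cc1` is not yet measured and differs from compound 3 by trifluoromethyl in place of tert-butyl on an aromatic carbon, the same change as from compound 1 to compound 2, at the same place. Resting on (the limit of > 100000 nM in this assay, at which 3 of the 3 values shown sit), the expected step is a step that the limit leaves unreadable from compound 3 to compound 4, small. Compound 4 is expected to give about 150000 nM, between 50000 nM and 500000 nM.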

Compound 4, half-maximal inhibitory concentration: > 100000 nM
Compound 4: no number, only a limit; the forecaster's own chance of this, stated with the estimate: 85%; the middle value does not contradict the limit.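

Going by these compounds alone, compound 4 gives > 100000 nM, which is a limit and not a number, so no step to it from compound 2 or compound 3 can be read. The compounds shown leave open whether either swap, trifluoromethyl for tert-butyl or bromo for chloro, changes the result at all: the limit of > 100000 nM in this assay, at which 4 of the 4 values shown sit.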